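A few compounds are considered here, and "the series" means these few. Any claim that something is new, unique, unknown or untested is made for them only; others in the source may bear on it.

In a functional assay on A549 cells (Homo sapiens) for antiproliferative activity, read by MTT assay, with a stated time of 48 h (a lower number here means a stronger inhibitor, a higher number a weaker inhibitor), compound 1 (`CCOc1cc(-c2ccc3[nH]ccc3c2)cn2c(-c3cc(OC)c(OC)c(OC)c3)nnc12`) gives 589 nM, compound 2 (`COc1cc(-c2nnc3c(OC)cc(-c4ccc5[nH]ccc5c4)cn23)cc(OC)c1OC`) gives 167 nM and compound 3 (`COc1cc(-c2nnc3c(OC(C)C)cc(-c4ccc5[nH]ccc5c4)cn23)cc(OC)c1OC`) gives 1250 nM, the highest of the three numbers. Compound 4 (`COc1cc(-c2nnc3c(OC4COC4)cc(-c4ccc5[nH]ccc5c4)cn23)cc(OC)c1OC`) has oxetan-3-yl in place of isopropyl on an oxygen on an aromatic ring. Among the measured compounds shown here, no measured step makes this exchange. The nearest evidence comes from changes to the group on that oxygen: a 3.5-fold lower number from compound 1 to compound 2 (0.55 log units; beyond the scatter), a 2.1-fold higher number from compound 1 to compound 3 (0.33 log units; beyond the scatter) and a 7.5-fold higher number from compound 2 to compound 3 (0.87 log units; beyond the scatter), all modest. None of these compounds carries a ring at that place, so the direction in this assay stays open and no large step is expected. The expected step is a 1.3-fold lower number from compound 3 to compound 4 (0.10 log units; within the scatter). Compound 4 is estimated at 1000 nM, with an expected range of 300 nM to 3500 nM.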

Compound 4, half-maximal inhibitory concentration: 9810 nM
Compound 4: middle estimate off by 9.8-fold (0.99 log units), on the low side, and the stated range ends below it.
By their numbers in this assay, from the lowest: compound 2; then compound 1; then compound 3; then compound 4.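

In this assay, oxetan-3-yl, the only ring on this oxygen among these compounds, gives the highest number of the four, with a 7.8-fold higher number from compound 3 to compound 4 (0.89 log units; beyond the scatter), a 17-fold higher number from compound 1 to compound 4 (1.22 log units; beyond the scatter) and a 59-fold higher number from compound 2 to compound 4 (1.77 log units; beyond the scatter). The numbers now rise in the order methyl, ethyl, isopropyl, oxetan-3-yl, and no compound shown goes against that order. No measurement shown accounts for the rise.

The compounds shown do not separate the effect of the ring from that of its oxygen. A cyclobutyl group on this oxygen would have the ring without the ring oxygen, and a 2-methoxyethyl chain would have an oxygen without the ring.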